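Capping the sulfur: compound 2 to compound 3

The source may report more compounds than this note shows. Statements on the series, on what has been measured and on what is new or still open speak of the compounds shown alone.

Within the data shown here, in a functional assay (spleen, spleen) for activation, with Mus musculus as the target (a lower number here means that less compound is needed, a higher number that more compound is needed for the effect), compound 2 `Nc1nc(S)nc2c1nc(O)n2Cc1ccccc1` gives 10 uM, the highest of the two numbers so far; compound 1 `COc1nc(N)c2nc(O)n(Cc3ccccc3)c2n1` gives 0.1 uM. Compound 3 `CSc1nc(N)c2nc(O)n(Cc3ccccc3)c2n1` carries the change (methyl in place of hydrogen on a sulfur). Among the measured compounds shown here, the one step that bears on it is a 100-fold higher number from compound 1 to compound 2 (2.00 log units; beyond the scatter), where the methoxy-to-sulfanyl exchange cost a great deal; compound 3 resembles compound 1 more closely than compound 2 does, so a sizeable drop toward the number of compound 1 is expected, a 33-fold lower number from compound 2 to compound 3 (1.52 log units; beyond the scatter). Compound 3 is therefore estimated at 0.3 uM, in the range 0.05 uM to 3 uM.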

Compound 3, minimum effective concentration: 0.1 uM
The estimate for compound 3 lay 3.0-fold (0.48 log units) above the measured number; low and high end bracket the measured number.
By their numbers in this assay, from the lowest: compounds 1 and 3 (each within the scatter of the next); then compound 2.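

Capping the sulfur gives a 100-fold lower number from compound 2 to compound 3 (2.00 log units; beyond the scatter), so the high number goes with the free sulfanyl and not with having a sulfur at this place. Methoxy and methylsulfanyl cannot be told apart here, with no change at the digits printed from compound 1 to compound 3 (within the scatter), which suggests that this position accepts either atom once it carries a methyl. No measurement at hand gives a reason for these steps.

As far as these compounds go, what remains open is how much size this position accepts beyond methyl. A longer chain such as butylsulfanyl, or an amine on the same aromatic carbon, would test whether the low number holds.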